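The compounds below may be only part of what the source reports. "The series", "measured", "known", "first", "only" and "open" are said of these compounds alone.

In an ADME assay for permeability, using PAMPA, at pH 4 (on this read-out higher numbers stand for higher permeability and lower numbers for lower permeability), compound 1 (`Cc1[nH]c2ccccc2c(=O)c1Br`) gives 8.19 10^-6 cm/s as its reading and compound 2 (`COc1cc2[nH]c(C)c(C(C)C)c(=O)c2cc1Cl`) gives 281 10^-6 cm/s as its reading. Compound 2 therefore holds the higher of the two numbers, and the gap between them lies beyond the usual scatter of repeated measurements. Compound 3 (`CCCCC/C=C/c1c(C)[nH]c2cc(OC)c(Cl)cc2c1=O`) has not yet been measured. Among the compounds with values here, its single change from compound 2 is hept-1-en-1-yl in place of isopropyl on an aromatic carbon with hept-1-en-1-yl in place of isopropyl on an aromatic carbon. Within the data shown here, no measured pair of compounds shows this change on its own, so the two readings in hand offer only a loose guide, and any forecast has to allow for a wide spread. A moderate fall in the reading is the expected direction, though a result close to that of compound 2 would not be surprising. The estimated change is a 2.3-fold lower number from compound 2 to compound 3 (0.37 log units; beyond the scatter) on this forecast. For compound 3 the expected reading is about 120 10^-6 cm/s in the middle, with an estimated range from 25 10^-6 cm/s up to 500 10^-6 cm/s as the likely span.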

Compound 3, apparent permeability: 280 10^-6 cm/s
Compound 3: the middle estimate sits 2.3-fold (0.37 log units) below what was measured; the range from low to high includes it.
By their numbers in this assay, from the lowest: compound 1; then compounds 3 and 2 (each within the scatter of the next).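

In this assay, within the data shown here, hept-1-en-1-yl in place of isopropyl on this aromatic carbon gives a 1.0-fold lower number from compound 2 to compound 3 (0.00 log units; within the scatter), the first reading of a change made at this position alone. The entering chain has 7 heavy atoms against the 3 of isopropyl, and it brings a double bond outside the aromatic rings, yet this read-out does not separate the two compounds, so at this position in this assay the two groups cannot be told apart. The data shown offer no independent measurement that would explain this match.

This is one step from a single pair of compounds, so it cannot show whether any other group at this carbon would behave the same way, or whether the same swap would do so on a different core. A saturated heptyl chain would show whether the double bond matters to the reading, while an amine or a carboxylic acid on the same carbon would test a very different kind of group, and the compounds shown leave all of these open.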